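The source may hold more compounds than are shown below. What is called first, only, known or untested is meant among the compounds shown, and "the series" means these compounds.

Three compounds sharing one core have numbers in a functional assay on M21 cells (Homo sapiens) for antiproliferative activity, read by sulforhodamine B assay, with a stated time of 48 h; a higher number here means a weaker inhibitor, a lower number a stronger inhibitor. Compound 1 `O=C1NCCN1c1ccc(S(=O)(=O)Nc2ccc(F)cc2)cc1` gives 230 nM, compound 2 `CCc1ccc(NS(=O)(=O)c2ccc(N3CCNC3=O)cc2)cc1` gives 480 nM, and compound 3 `Cc1cc(C)cc(NS(=O)(=O)c2ccc(N3CCNC3=O)cc2)c1` gives 63 nM, the lowest number and so the strongest of the three. Compound 4 `Cc1ccccc1NS(=O)(=O)c1ccc(N2CCNC2=O)cc1` has not yet been measured. It carries 2-methylphenyl in place of 3,5-dimethylphenyl on a sulfonamide nitrogen.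

Two measured steps change the group on that nitrogen to 3,5-dimethylphenyl: a 3.7-fold lower number from compound 1 to compound 3 (0.56 log units; beyond the scatter) and a 7.6-fold lower number from compound 2 to compound 3 (0.88 log units; beyond the scatter). A third, a 2.1-fold higher number from compound 1 to compound 2 (0.32 log units; beyond the scatter), is a smaller shift between the two compounds without 3,5-dimethylphenyl. Within the data shown here, no measured compound carries 2-methylphenyl, so there is no direct precedent for it. Both measured compounds lacking 3,5-dimethylphenyl stand higher than compound 3, with compound 1 at 230 nM and compound 2 at 480 nM. Losing that group is therefore expected to move the number upward in this assay, by a modest step beyond the scatter, similar in size to those two steps. The expected step is a 4.0-fold higher number from compound 3 to compound 4 (0.60 log units; beyond the scatter). The estimate for compound 4 is 250 nM, with an expected range of 80 nM to 800 nM.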

Compound 4, half-maximal inhibitory concentration: 150 nM
For compound 4 the middle estimate is 1.7-fold (0.22 log units) above the measured one; low and high end bracket the measured number.
By their numbers in this assay, from the lowest: compound 3; then compounds 4 and 1 (each within the scatter of the next); then compound 2.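

In this assay the change to 2-methylphenyl on the sulfonamide nitrogen gives a 2.4-fold higher number from compound 3 to compound 4 (0.38 log units; beyond the scatter) and so keeps compound 3 as the strongest of the four, yet this aryl group does not carry the full penalty seen with 4-ethylphenyl. That gap appears as a 3.2-fold lower number from compound 2 to compound 4 (0.51 log units; beyond the scatter) in the same assay, whereas a 1.5-fold lower number from compound 1 to compound 4 (0.19 log units; within the scatter) leaves the 2-methylphenyl and 4-fluorophenyl compounds indistinguishable. The position therefore now separates three levels rather than simply 3,5-dimethylphenyl against everything else: 3,5-dimethylphenyl alone at the low end, 2-methylphenyl and 4-fluorophenyl together in the middle, and 4-ethylphenyl at the high end.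

The four compounds leave open how the number would respond to a methoxy group, an amine or a carboxylic acid on this aromatic ring, or to a saturated ring such as cyclohexyl on the sulfonamide nitrogen in place of the aryl group. They also say nothing about changes elsewhere on the shared core, and no measurement here accounts for the differences among these aryl groups.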